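The source may report more compounds than this note shows. Statements on the series, on what has been measured and on what is new or still open speak of the compounds shown alone.

Working notes on the series. The shared core carries a methanesulfonamido-substituted aryl on the amide side and a pivalate ester on the other; compound 1 `Cc1ccc(CC(CNC(=O)C2(c3ccc(NS(C)(=O)=O)cc3)CC2)COC(=O)C(C)(C)C)cc1C` has hydrogen on the aromatic carbon of interest, compound 2 `COc1cc(C2(C(=O)NCC(COC(=O)C(C)(C)C)Cc3ccc(C)c(C)c3)CC2)ccc1NS(C)(=O)=O` methoxy, and compound 3 `Cc1ccc(CC(CNC(=O)C(C)(C)c2ccc(NS(C)(=O)=O)c(F)c2)COC(=O)C(C)(C)C)cc1C` fluoro together with a gem-dimethyl linker in place of the cyclopropane. In an assay on CHO cells for displacement of a labelled ligand from transient receptor potential cation channel subfamily V member 1 (Rattus norvegicus) (a lower number here means a stronger inhibitor, a higher number a weaker inhibitor), compound 2 gives 239 nM. Compound 3 gives 280 nM and compound 1 gives 396 nM, and both of these stand within the scatter of compound 2, so no ranking among the three is supported by the numbers. Going by the values given here, the single one-point step recorded, a 1.7-fold lower number from compound 1 to compound 2 (0.22 log units; within the scatter), is itself within the scatter.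

Compound 4 `Cc1ccc(CC(CNC(=O)C2(c3ccc(NS(C)(=O)=O)c(F)c3)CC2)COC(=O)C(C)(C)C)cc1C` is the next point: fluoro in place of methoxy on an aromatic carbon. Among the compounds with values here, no measured step replaces methoxy with fluoro on this carbon, and compound 3 and compound 4 differ also in the linker, so their values cannot be read as a step. Within the data shown here, the one step that bears on the carbon in question, from compound 1 to compound 2, was within the scatter, and compound 3 with fluoro at that carbon gives 280 nM in this assay. The expectation for the step from compound 2 to compound 4 is therefore a 1.2-fold higher number from compound 2 to compound 4 (0.07 log units; within the scatter), with no change beyond the scatter. Compound 4 is estimated at 280 nM, within a range from 120 nM to 650 nM.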

Compound 4, inhibition constant: 1580 nM
Compound 4: the middle estimate sits 5.6-fold (0.75 log units) below what was measured; the whole stated range lies below it.
By their numbers in this assay, from the lowest: compounds 2, 3 and 1 (each within the scatter of the next); then compound 4.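

In this assay, the carbon ortho to a methanesulfonamido group now shows a change beyond the scatter, which the step from hydrogen to methoxy had not shown: fluoro in place of methoxy gives a 6.6-fold higher number from compound 2 to compound 4 (0.82 log units; beyond the scatter), and fluoro in place of hydrogen gives a 4.0-fold higher number from compound 1 to compound 4 (0.60 log units; beyond the scatter). With the cyclopropane linker, the position therefore does not accept every small group alike: hydrogen and methoxy stand within the scatter of each other, while fluoro sits apart from both, on the side of the higher number. The result for fluoro also depends on the rest of the molecule, since compound 3, with the gem-dimethyl linker, gives 280 nM, while compound 4, with the cyclopropane linker, gives 1580 nM.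

Nothing at hand bears on the reason that fluoro departs from hydrogen and methoxy at this carbon. As far as these compounds go, whether chloro, hydroxyl or an amine on this carbon would stand with fluoro or with hydrogen and methoxy stays open, as does the value of the gem-dimethyl linker with hydrogen or methoxy at this position.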